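Methoxycarbonyl to (Morpholin-4-yl)carbonyl: A Single Step

The source may report more compounds than this note shows. Statements on the series, on what has been measured and on what is new or still open speak of the compounds shown alone.

Compound 1, `COC(=O)/C=C/c1ccncc1-c1ccc2ccccc2c1`: 40.6 nM
Compound 2, `COC(=O)COc1ccncc1-c1ccc2ccccc2c1`: "not determined" (no result reported)

Two compounds of this set have been run through an assay on a protein complex for inhibition of CDK8/Cyclin C (Homo sapiens), with a stated time of 1 h; on this read-out higher numbers stand for weaker inhibition and lower numbers for stronger inhibition. In this assay, going by the values given here, compound 1 gives 40.6 nM, the only number the set holds; for compound 2 the entry in this assay reads "not determined" (no result reported), so compound 1 stands alone and can be placed against nothing else. Among the compounds with values here, no pair of measured compounds differs in a single place, so no step between measured compounds has been worked out.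

Compound 3, `O=C(/C=C/c1ccncc1-c1ccc2ccccc2c1)N1CCOCC1`, is the next one to be tested in this assay. It departs from compound 1 by morpholin-4-yl in place of methoxy on a carbonyl carbon. Cut one bond further out, the change reads methoxycarbonyl to (morpholin-4-yl)carbonyl. Within the data shown here, with no measured step of this kind to lean on, the expectation is a modest step, a 1.2-fold lower number from compound 1 to compound 3 (0.06 log units; within the scatter), in either direction no larger than the usual scatter. Compound 3 is therefore expected to come in at 35 nM, with a range from 10 nM to 120 nM.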

Compound 3, half-maximal inhibitory concentration: 60.3 nM
Estimate against measurement, compound 3: 1.7-fold (0.24 log units) below, and the stated range covers the measured number.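

In this assay, the first step read at this place, morpholin-4-yl in place of methoxy on a carbonyl carbon, comes to a 1.5-fold higher number from compound 1 to compound 3 (0.17 log units; within the scatter), so the two numbers cannot be told apart. The change is not a small one in size: a group of 2 heavy atoms and no ring leaves, and one of 6 heavy atoms with a six-membered non-aromatic ring enters, yet the read-out stays within the usual scatter for this single pair, which shows that at least this one larger group can sit on the carbonyl carbon without a measurable loss or gain. Nothing measured on these compounds beyond this read-out bears on the result, so the step stands as an observation without an explanation.

One step cannot show whether this holds for other groups in the same place, such as a carboxylic acid, a simple open-chain amine or an amide with a longer chain. The compounds shown also leave open how far the double-bonded chain carbon that carries the carbonyl can be changed while the number holds.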